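A few compounds are considered here, and "the series" means these few. Any claim that something is new, unique, unknown or untested is made for them only; others in the source may bear on it.

Measured compounds in a functional assay on Raji cells (Homo sapiens); on this read-out lower numbers stand for stronger inhibition and higher numbers for weaker inhibition:
compound 1 `O=c1[nH]c(=O)n([C@@H]2O[C@H](COP(=O)(O)O)[C@@H](O)[C@H]2O)cc1Br`, > 1000 ug/mL
compound 2 `O=c1[nH]c(=O)n([C@@H]2O[C@@H]3COP(=O)(O)O[C@H]3[C@H]2O)cc1I`, 722 ug/mL
compound 3 `O=c1[nH]c(=O)n([C@@H]2O[C@@H]3COP(=O)(O)O[C@H]3[C@H]2O)cc1Br`, 241 ug/mL.

For compound 1 the value in this assay is a limit and not a number: the limit of > 1000 ug/mL in this assay, at which 1 of the 3 values shown sits. Compound 3 and compound 2 differ by iodo in place of bromo on an aromatic carbon; in this assay the result is a 3.0-fold higher number from compound 3 to compound 2 (0.48 log units; beyond the scatter). Compound 4 `O=c1[nH]c(=O)n([C@@H]2O[C@H](COP(=O)(O)O)[C@@H](O)[C@H]2O)cc1I` is not yet measured; it differs from compound 1 by iodo in place of bromo on an aromatic carbon, the same change at the same place. How the core of compound 1 differs from the core of compound 3 is not broken down here. The step expected in this assay is a step that the limit leaves unreadable from compound 1 to compound 4, resting on the measured step of a 3.0-fold higher number from compound 3 to compound 2 (0.48 log units; beyond the scatter). Compound 4 is therefore expected at 3000 ug/mL, most likely reported again only as a limit.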

Compound 4, concentration for 50% inhibition: > 1000 ug/mL
Compound 4 gave a limit, no number; the forecaster's own chance of this, stated with the estimate: 90%; the middle value does not contradict the limit.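

In this assay compound 1 and compound 4 both stand only as limits, so no step for iodo in place of bromo can be read between them: the limit of > 1000 ug/mL in this assay, at which 2 of the 4 values shown sit.

Going by these compounds, whether this change acts on the core of compound 1 as it does on the core of compound 3 stays open.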